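This account rests on a few compounds, and the source may have more. Where it says the series, first, only, none or still open, it means among the compounds named here.

Series notes. Compound 1 `COc1ccc(-c2cc3cc(C)ccc3c(-c3cccc(O)c3)n2)cc1OC` gives 1.7% in an assay on isolated protein for inhibition of DNA topoisomerase 1 (Homo sapiens), with a stated time of 30 min, tested at 100 uM; a lower number here means a weaker effect, a higher number a stronger effect of the compound at the concentration tested. Compound 2 `COc1cccc(-c2nc(-c3ccc(OC)c(OC)c3)cc3cc(C)ccc23)c1` gives 2.9% in this assay, the change being a number 1.2 percentage points higher from compound 1 to compound 2 (within the scatter). Compound 3 `COc1ccc(-c2cc3cc(C)ccc3c(-c3cccc(N)c3)n2)cc1OC` gives 7.2% in this assay; it is reached by a number 5.5 percentage points higher from compound 1 to compound 3 (within the scatter) and by a number 4.3 percentage points higher from compound 2 to compound 3 (within the scatter), so none of the three numbers stands apart from the others, and the whole set sits in the region of negligible inhibition at the test concentration.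

Compound 4 `COc1ccc(-c2cc3cc(C)ccc3c(-c3ccc(O)cc3)n2)cc1OC` is not yet measured. It is derived from compound 3 by 4-hydroxyphenyl in place of 3-aminophenyl on an aromatic carbon. Going by the values given here, the steps that bear on this are the exchange of hydroxy for amino between compound 1 and compound 3, a number 5.5 percentage points higher from compound 1 to compound 3 (within the scatter), and the exchange of methoxy for amino between compound 2 and compound 3, a number 4.3 percentage points higher from compound 2 to compound 3 (within the scatter), both within the scatter. Returning to a hydroxyphenyl is therefore expected to give no step beyond the scatter in this assay, the expected step being a number 4.2 percentage points lower from compound 3 to compound 4 (within the scatter). Compound 4 is expected to give 3%, in the range 0% to 12%.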

Compound 4, a percentage reported as inhibition, at one concentration (the size of the read-out at that concentration, not a potency): 0.3%
For compound 4 the middle estimate is 2.7 percentage points above the measured one; measured number inside the range.
By their numbers in this assay, from the lowest: compounds 4, 1, 2 and 3 (each within the scatter of the next).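

Moving the hydroxy group from the 3-hydroxyphenyl of compound 1 to the 4-hydroxyphenyl of compound 4 is the first change of a group's place on this ring, and it gives a number 1.4 percentage points lower from compound 1 to compound 4 (within the scatter) in this assay. The comparisons with the other two rings, a number 2.6 percentage points lower from compound 2 to compound 4 (within the scatter) and a number 6.9 percentage points lower from compound 3 to compound 4 (within the scatter), point the same way: at this aromatic carbon next to the ring nitrogen, neither the kind of group nor its place on the phenyl ring has moved the read-out beyond the scatter. No measurement shown here accounts for these numbers.

On these data alone, with all four numbers this close together, it remains open whether any change at this position can raise inhibition. A 4-aminophenyl, a carboxylic acid or a longer aminoalkyl chain on this ring could test that.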